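This account rests on a few compounds, and the source may have more. Where it says the series, first, only, none or still open, it means among the compounds named here.

Measured compounds:
compound 1 `O=C(Nc1cccc(-c2oc3cc(-c4ccc(F)cc4)ccc3c(=O)c2O)c1)c1ccc(F)cc1` — 8590 nM
compound 2 `Cc1ccc(C(=O)Nc2cccc(-c3oc4cc(-c5ccc(F)cc5)ccc4c(=O)c3O)c2)cc1` — 2400 nM

In a functional assay on MCF7 cells (Homo sapiens) for antiproliferative activity, read by CCK-8 assay, with a stated time of 72 h (on this read-out lower numbers stand for stronger inhibition and higher numbers for weaker inhibition), compound 2 stands lowest of the two numbers shown, its nearest neighbour being compound 1, which differed only by a 3.6-fold lower number from compound 1 to compound 2 (0.55 log units; beyond the scatter). Compound 3 `Cc1ccccc1C(=O)Nc1cccc(-c2oc3cc(-c4ccc(F)cc4)ccc3c(=O)c2O)c1` carries 2-methylphenyl in place of 4-methylphenyl on a carbonyl carbon. Within the data shown here, no measured step moves the methyl around the ring; the one step known concerns a different swap at the same carbonyl-bound ring, so it gives no direct guide. Compound 3 is therefore expected to show no step beyond the scatter, a 1.5-fold higher number from compound 2 to compound 3 (0.16 log units; within the scatter), with an estimated 3500 nM in this assay, likely between 1200 nM and 10000 nM.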

Compound 3, half-maximal inhibitory concentration: 2280 nM
The estimate for compound 3 lay 1.5-fold (0.19 log units) above the measured number; measured number inside the range.
By their numbers in this assay, from the lowest: compounds 3 and 2 (each within the scatter of the next); then compound 1.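

In this assay, 2-methylphenyl and 4-methylphenyl on the carbonyl carbon cannot be told apart (a 1.1-fold lower number from compound 2 to compound 3 (0.02 log units; within the scatter)), so among the compounds shown, the place of the methyl on this ring makes no difference beyond the scatter. The step away from 4-fluorophenyl holds for the second methyl compound as well (a 3.8-fold lower number from compound 1 to compound 3 (0.58 log units; beyond the scatter)), so it is not tied to a single methyl placement. No supporting data explain why the two methyl compounds match.

Still open, as far as these compounds go, is how a methoxy group, an amine or a carboxylic acid in place of the methyl would read here. Whether a longer chain such as propyl would keep these numbers is also unknown.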